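The compounds below may be only part of what the source reports. "The series", "measured", "known", "first", "only" and "open" are said of these compounds alone.

In a physicochemical assay for lipophilicity (on this read-out lower numbers stand for lower lipophilicity and higher numbers for higher lipophilicity), three compounds sharing one core have been measured. Compound 1 (`Cc1ccc(C2C[C@@]3(ON2c2ccccc2)C(=O)O[C@@H]2[C@H]3CC[C@H](C)[C@]3(O)C=CC(=O)[C@@]23C)cc1`) gives 3.64, compound 2 (`C[C@H]1CC[C@@H]2[C@@H](OC(=O)[C@]23CC(c2ccccc2Cl)N(c2ccccc2)O3)[C@]2(C)C(=O)C=C[C@@]12O`) gives 3.87 and compound 3 (`C[C@H]1CC[C@@H]2[C@@H](OC(=O)[C@]23CC(c2c(F)c(F)c(F)c(F)c2F)N(c2ccccc2)O3)[C@]2(C)C(=O)C=C[C@@]12O`) gives 3.72. Compound 3 therefore cannot be separated from either of the others, with a number 0.08 log units higher from compound 1 to compound 3 (within the scatter) and a number 0.15 log units lower from compound 2 to compound 3 (within the scatter).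

Compound 4 (`C[C@H]1CC[C@@H]2[C@@H](OC(=O)[C@]23CC(c2ccc([N+](=O)[O-])cc2)N(c2ccccc2)O3)[C@]2(C)C(=O)C=C[C@@]12O`) keeps the core but carries 4-nitrophenyl in place of 2,3,4,5,6-pentafluorophenyl on a saturated ring carbon. The entering group brings hydrogen-bond acceptors and a double bond outside aromatic rings, neither of which the leaving group has.

The measured steps that bear on this change are the exchanges at the same carbon. Besides the two already given, there is a number 0.23 log units higher from compound 1 to compound 2 (within the scatter), and none of the three leaves the scatter. Among the measured compounds shown here, none of them involves 4-nitrophenyl, however, so the series offers no direct precedent, and the range has to stay wide. A small step in this assay is expected, lower if anything and not beyond the scatter. The expected change is a number 0.22 log units lower from compound 3 to compound 4 (within the scatter). For compound 4 the estimated value is 3.5, with an expected range from 3.1 to 3.85.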

Compound 4, partition coefficient: 3.15
Estimate against measurement, compound 4: 0.35 log units above; measured number inside the range.
By their numbers in this assay, from the lowest: compound 4; then compounds 1, 3 and 2 (each within the scatter of the next).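

In this assay, among the compounds shown here, the exchanges at this saturated ring carbon had so far all stayed within the scatter, and 4-nitrophenyl is the first group there to leave it, with a number 0.57 log units lower from compound 3 to compound 4 (beyond the scatter) and with a number 0.72 log units lower from compound 2 to compound 4 (beyond the scatter) as well. The same holds for nitro in place of methyl on an aromatic carbon, with a number 0.49 log units lower from compound 1 to compound 4 (beyond the scatter), so the position can separate compounds on this read-out, and compound 4 stands apart from three compounds that cannot be separated from their nearest neighbours. Nothing available gives a reason for this separation, and the hydrogen-bond acceptors and the double bond counted for 4-nitrophenyl remain only a structural difference.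

With a single nitro compound, the shift cannot be assigned to the nitro group in general or to this one 4-nitrophenyl arrangement. From the compounds shown here alone, it also stays open whether an amine, a carboxylic acid or a nitrile on the same aromatic ring would give a step of similar size, or whether a group of that kind would stay within the scatter of compounds 1, 2 and 3.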